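The source may hold more compounds than are shown below. What is called first, only, known or untested is meant among the compounds shown, and "the series" means these compounds.

In a functional assay on B16 cells (Mus musculus) for cytotoxicity, read by CCK-8 assay, with a stated time of 24 h (on this read-out lower numbers stand for stronger inhibition and higher numbers for weaker inhibition), compound 1 `COc1ccccc1Oc1c(N)nc(-c2cccc(C)c2)nc1Cl` gives 13100 nM, while compound 2 `COc1ccc(-c2nc(N)c(Oc3ccccc3OC)c(Cl)n2)cc1` gives 47800 nM, the higher of the two numbers. Compound 3 `COc1ccccc1Oc1c(N)nc(-c2cccc(F)c2)nc1Cl` is still unmeasured and differs from compound 2 in one place: 3-fluorophenyl in place of 4-methoxyphenyl on an aromatic carbon. For the measured compounds named here, only one measured step bears on this change: a 3.6-fold higher number from compound 1 to compound 2 (0.56 log units; beyond the scatter), seen when 4-methoxyphenyl replaced 3-methylphenyl. Going by the values given here, compound 3 also lacks the 4-methoxyphenyl, so a modest move to a lower number is expected in this assay, with no measurement yet for a 3-fluorophenyl group. The expected change is a 2.5-fold lower number from compound 2 to compound 3 (0.40 log units; beyond the scatter). For compound 3 the estimated value is 19000 nM, within an expected range of 8000 nM to 45000 nM.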

Compound 3, half-maximal inhibitory concentration: 21700 nM
Beside the measured number, compound 3's estimate is 1.1-fold (0.06 log units) below it; the measured number falls inside the stated range.
By their numbers in this assay, from the lowest: compounds 1 and 3 (each within the scatter of the next); then compound 2.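

In this assay, the 4-methoxyphenyl group of compound 2 now stands apart from two other groups at this position between two ring nitrogen atoms: 3-fluorophenyl in its place gives a clear step (a 2.2-fold lower number from compound 2 to compound 3 (0.34 log units; beyond the scatter)). Fluoro and methyl on the phenyl ring cannot be told apart here (a 1.7-fold higher number from compound 1 to compound 3 (0.22 log units; within the scatter)). Nothing available explains these differences. Still open, going by these compounds, is whether the methoxy group itself or its place on the ring sets compound 2 apart, which 3-methoxyphenyl and 4-fluorophenyl would separate. An amine on that phenyl ring is also untested among these compounds.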